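Pyridyl to tolyl on the biaryl: expected gain in response

This account rests on a few compounds, and the source may have more. Where it says the series, first, only, none or still open, it means among the compounds named here.

Compound 1 `Cc1ccc(-c2ccccc2OC(C)C2=NCCN2)cc1` gives 0.46 in a functional assay on CHO cells for agonist activity at Alpha-2C adrenergic receptor (Homo sapiens); a higher number here means a larger maximal response, a lower number a smaller maximal response.
Compound 2 `CC(Oc1ccccc1-c1ccncc1)C1=NCCN1` gives < 0.3 in this assay, which is a limit of the assay and not a number.
Compound 3 `CC(Nc1ccccc1-c1ccccc1)C1=NCCN1` gives 0.7 in this assay.

Compound 2 thus stands at the floor of the series: its response reached only (the limit of < 0.3 in this assay, at which 1 of the 3 values shown sits), so nothing more precise is known of it. Among the compounds with values here, the one step that bears on the coming change is a number at least 0.16 lower from compound 1 to compound 2 (beyond the scatter), and the change from compound 2 to compound 4 `Cc1ccccc1-c1ccccc1OC(C)C1=NCCN1` runs in the opposite sense: 2-methylphenyl in place of pyridin-4-yl on an aromatic carbon. This largely undoes the earlier change, with the methyl now sitting on a different carbon of the entering ring. Since putting pyridin-4-yl in place of 4-methylphenyl cost a modest step in this assay, compound 4 is expected to recover a step of about the same size upward, beyond the scatter, landing near where compound 1 stands. The estimated step is a number at least 0.15 higher from compound 2 to compound 4 (beyond the scatter). Compound 4 is therefore estimated at 0.45, between 0.3 and 0.65.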

Compound 4, intrinsic activity: the largest response reached, as a fraction of the reference agonist's: 0.45
Beside the measured number, compound 4's estimate shows no gap at the digits printed; low and high end bracket the measured number.
By their numbers in this assay, from the lowest: compounds 4 and 1 (each within the scatter of the next); then compound 3. At a limit, below all of these: compound 2.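

In this assay, 2-methylphenyl in place of pyridin-4-yl on this aromatic carbon gives a number at least 0.15 higher from compound 2 to compound 4 (beyond the scatter), so a methyl-bearing carbon ring restores a response here whichever carbon carries the methyl. The methyl's place on that ring makes no readable difference, since 2-methylphenyl in place of 4-methylphenyl gives a number 0.010 lower from compound 1 to compound 4 (within the scatter). The value for compound 2 remains a limit of the assay and not a number: the limit of < 0.3 in this assay, at which 1 of the 4 values shown sits.

The compounds shown leave open whether the core of compound 1 carrying a plain phenyl would stand with compound 4 or with compound 2, which would separate the methyl from the ring nitrogen of pyridin-4-yl. They also leave open how a methoxy group or a chlorine atom in place of the methyl would read in this assay.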